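The source may hold more compounds than are shown below. What is called first, only, known or untested is meant among the compounds shown, and "the series" means these compounds.

Measured compounds in an assay on HEK293 cells for agonist activity at Toll-like receptor 8 (Homo sapiens), read by a luciferase reporter, with a stated time of 6 h; on this read-out higher numbers stand for an effect only at larger amounts of compound and lower numbers for an effect already at smaller amounts:
- compound 1, `CCCCNc1nc(N)nc2c1CCN(C)C2`: 0.2 uM
- compound 2, `CCCCNc1nc(N)nc2c1CN(Cc1cccc3ccccc13)CC2`: 0.43 uM
- compound 3, `CCCCNc1nc(N)nc2c1CN(Cc1ccccn1)CC2`: 0.07 uM

Compound 3 gives the lowest number of the three in this assay. The nearest is compound 1, whose number is higher by a step beyond the scatter; compound 2 lies further off, also beyond the scatter. Both compounds carrying a methyl-linked aromatic ring on the ring amine, compound 2 and compound 3, bracket compound 1, so no single direction follows from the shown values.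

Compound 4, `CCCCNc1nc(N)nc2c1CN(C(=O)c1csnn1)CC2`, has not been measured. Its change from compound 3: (1,2,3-thiadiazol-4-yl)carbonyl in place of (pyridin-2-yl)methyl on an amine nitrogen in a ring. The substituent is thus no longer joined by a methylene but by a carbonyl, and the ring is now five-membered with three hetero atoms. Among the measured compounds shown here, no measured pair shows this kind of change, so the expectation rests on the spread among compounds 1, 2 and 3 alone. A step toward a higher number than compound 3, beyond the scatter, is expected: a 4.3-fold higher number from compound 3 to compound 4 (0.63 log units; beyond the scatter). The estimate for compound 4 is 0.3 uM, with a range from 0.07 uM to 1.5 uM.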

Compound 4, minimum effective concentration: 0.1 uM
The estimate for compound 4 lay 3.0-fold (0.48 log units) above the measured number; measured number inside the range.
By their numbers in this assay, from the lowest: compounds 3, 4 and 1 (each within the scatter of the next, the first and the last beyond it); then compound 2.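

In this assay, among the compounds shown here, placing (1,2,3-thiadiazol-4-yl)carbonyl in place of (pyridin-2-yl)methyl on the amine nitrogen in a ring gives a 1.4-fold higher number from compound 3 to compound 4 (0.15 log units; within the scatter), the first step between compounds that differ in one place. At this position, the read-out therefore does not separate a carbonyl-joined, five-membered aromatic ring with three hetero atoms from a methylene-joined, six-membered aromatic ring with one hetero atom. Nothing available accounts for this result.

The linker and the ring change together in this step, so their separate contributions remain unresolved. Going by these compounds, a (pyridin-2-yl)carbonyl group or a (1,2,3-thiadiazol-4-yl)methyl group on the same nitrogen would change only one of the two, and how either would read out remains open.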